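Aryl substituent swap: chloro to trifluoromethyl

The source may report more compounds than this note shows. Statements on the series, on what has been measured and on what is new or still open speak of the compounds shown alone.

In a functional assay (Cavia porcellus) with sulfonylurea receptors; K-ATP channels (Homo sapiens) as the target (on this read-out lower numbers stand for stronger inhibition and higher numbers for weaker inhibition), compound 1 `CC(O)(C(=O)Nc1ccc(S(=O)(=O)c2cccc(O)c2)cc1)C(F)(F)F` gives 18000 nM. Compound 2 `CC(O)(C(=O)Nc1ccc(S(=O)(=O)c2cccc(Cl)c2)cc1)C(F)(F)F` carries chloro in place of hydroxy on an aromatic carbon; in this assay compound 2 gives 10000 nM, the lower of the two numbers recorded, though the step of a 1.8-fold lower number from compound 1 to compound 2 (0.26 log units; within the scatter) is within the scatter, so compound 2 and compound 1 cannot be separated on this read-out. Compound 3 `CC(O)(C(=O)Nc1ccc(S(=O)(=O)c2cccc(C(F)(F)F)c2)cc1)C(F)(F)F` is the next member: trifluoromethyl in place of chloro on an aromatic carbon, at a position meta to a large group. Among the compounds with values here, the only step measured so far, a 1.8-fold lower number from compound 1 to compound 2 (0.26 log units; within the scatter), concerns an exchange at the same aromatic carbon and was small; no step involving trifluoromethyl has been measured in this assay. On that basis no step beyond the scatter is expected, the estimated step being a 1.3-fold lower number from compound 2 to compound 3 (0.10 log units; within the scatter). For compound 3 the estimated value in this assay is 8000 nM, within a range from 3000 nM to 25000 nM.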

Compound 3, half-maximal inhibitory concentration: > 30000 nM
Compound 3: only a limit was reported (the forecaster's own chance of this, stated with the estimate: 10%); middle value at least 3.7-fold (0.57 log units) away from the limit.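

Within the data shown here, on the aromatic carbon meta to a large group, trifluoromethyl in place of chloro gives the first step in this assay that leaves the scatter: an at least 3.0-fold higher number from compound 2 to compound 3 (0.47 log units; beyond the scatter). Against the hydroxy member, the reading is an at least 1.6-fold higher number from compound 1 to compound 3 (0.22 log units; that floor lies within the scatter), so compound 3 is not clearly separated from compound 1. The result for compound 3 is a limit and not a number, so both steps are floors: the limit of > 30000 nM in this assay, at which 1 of the 3 values shown sits.

The compounds shown leave open whether methyl, fluoro, an amine or a carboxylic acid on this same carbon would give a number in line with compound 2 or a lower one. They also leave open how trifluoromethyl in place of chloro would read on another carbon of this ring.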